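Oxo-fused bicyclic series: whole-organism inhibition at one dose

A few compounds are considered here, and "the series" means these few. Any claim that something is new, unique, unknown or untested is made for them only; others in the source may bear on it.

Measured so far:
compound 1, `COc1cc2[nH]c(=O)c(=O)oc2cc1OC`: 45%
compound 2, `COC(=O)c1cc(OC)c2oc(=O)c(=O)[nH]c2c1`: 35%

In a functional assay on the whole organism for inhibition, with Rattus norvegicus as the target, at a dose of 25 mg/kg (a lower number here means less inhibition, a higher number more inhibition at the dose given (going by the name of the read-out)), compound 2 gives 35%, and compound 1 gives 45%, the two numbers lying within the usual scatter of each other. Compound 3, `C=CCc1cc(OC)c2oc(=O)c(=O)[nH]c2c1`, differs from compound 2 by allyl in place of methoxycarbonyl on an aromatic carbon. Within the data shown here, no step between two measured compounds of this kind is available, so nothing measured points in either direction for this change. The expectation is a step from compound 2 to compound 3 of no change at the digits printed from compound 2 to compound 3 (within the scatter), not beyond the scatter. Compound 3 is therefore estimated at 35%, within 15% to 60%.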

Compound 3, a percentage reported as inhibition, in the whole organism at one dose (the size of the read-out at that dose, not a potency): 77%
Beside the measured number, compound 3's estimate is 42 percentage points below it, and the stated range ends below it.
By their numbers in this assay, from the lowest: compounds 2 and 1 (each within the scatter of the next); then compound 3.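

In this assay, allyl in place of methoxycarbonyl on this aromatic carbon gives a number 42 percentage points higher from compound 2 to compound 3 (beyond the scatter), so the substituent at this position can strongly change the read-out at this dose. The change replaces a group containing oxygen with one of carbon only, while both groups keep a double bond outside the aromatic rings. Nothing measured explains the step.

A propyl group would show whether the allyl double bond is needed. On these data alone, how an amine or a carboxylic acid at this carbon would compare remains open.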